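The source may hold more compounds than are shown below. What is called first, only, known or untested is meant among the compounds shown, and "the series" means these compounds.

Working notes on the series in an ADME assay on cells (Peritoneal macrophage, Mus musculus) for cytotoxicity, read by MTT assay, with a stated time of 24 h; on this read-out higher numbers stand for lower toxicity in this test and lower numbers for higher toxicity in this test

Three measured compounds share one core and differ only in the group on an aromatic carbon. Compound 1 `Cc1ccc(N/C(=N\C(=O)c2ccccc2)NCc2ccccc2)cc1` carries methyl there, compound 2 `COc1ccc(N/C(=N\C(=O)c2ccccc2)NCc2ccccc2)cc1` methoxy, and compound 3 `O=C(/N=C(/NCc1ccccc1)Nc1ccc(F)cc1)c1ccccc1` fluoro. In this assay compound 1 gives 876000 nM. Compound 2 gives 837000 nM. Compound 3 gives 866000 nM, the second highest of the three numbers, with compound 1 nearest and compound 2 furthest, both within the scatter of it.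

The steps between the measured compounds are all small: a 1.0-fold lower number from compound 1 to compound 2 (0.02 log units; within the scatter), a 1.0-fold lower number from compound 1 to compound 3 (0.00 log units; within the scatter), and a 1.0-fold higher number from compound 2 to compound 3 (0.01 log units; within the scatter). Each swap of the group on this aromatic carbon left the read-out essentially unchanged.

Compound 4 `O=C(/N=C(/NCc1ccccc1)Nc1ccc(Br)cc1)c1ccccc1` is not yet measured. The change from compound 3 is bromo in place of fluoro on an aromatic carbon. All three measured steps bear on it, since each exchanges the group at the same carbon, and none moved the number beyond the scatter. No step beyond the scatter is therefore expected here either: the expected step is a 1.0-fold lower number from compound 3 to compound 4 (0.00 log units; within the scatter). For compound 4 the estimate in this assay is 860000 nM, with a range from 600000 nM to 1200000 nM.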

Compound 4, half-maximal cytotoxic concentration: 738000 nM
Compound 4: middle estimate off by 1.2-fold (0.07 log units), on the high side, within the range that was stated.
By their numbers in this assay, from the lowest: compounds 4, 2, 3 and 1 (each within the scatter of the next).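

In this assay, the exchange of fluoro for bromo at this aromatic carbon, para to a large group, stays within the scatter (a 1.2-fold lower number from compound 3 to compound 4 (0.07 log units; within the scatter)), as do the exchanges of methoxy (a 1.1-fold lower number from compound 2 to compound 4 (0.05 log units; within the scatter)) and methyl (a 1.2-fold lower number from compound 1 to compound 4 (0.07 log units; within the scatter)) for bromo. The earlier compounds shown here held a single halogen at this carbon; the pair 4-fluorophenyl and 4-bromophenyl now shows that one halogen in place of another gives no separation on this read-out, and the set of four groups remains unresolved. No supporting measurement is available to explain this lack of separation.

On these data alone, whether the read-out holds with an amine, a carboxylic acid or a longer chain at this carbon stays open. The compounds shown also leave open what exchanges elsewhere on the shared core would do.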